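Chromone acrylamides: amide nitrogen substituents, first look

The compounds below may be only part of what the source reports. "The series", "measured", "known", "first", "only" and "open" are said of these compounds alone.

Two amides of the shared core have been measured. Compound 1 `COc1ccc2c(=O)c(/C=C/C(=O)Nc3ccccc3OC)coc2c1` carries a 2-methoxyphenyl on the amide-type nitrogen; in a functional assay (QGY7701 cells, Homo sapiens) for inhibition, read by MTT assay, with a stated time of 48 h (on this read-out lower numbers stand for stronger inhibition and higher numbers for weaker inhibition), compound 1 gives 17600 nM. Compound 2 `COc1ccc2c(=O)c(/C=C/C(=O)NCc3ccc(C)cc3)coc2c1` carries a 4-methylbenzyl in the same place, and in this assay compound 2 gives 10200 nM. The step of a 1.7-fold lower number from compound 1 to compound 2 (0.24 log units; within the scatter) is the only one available, and it does not separate the two compounds: compound 2 and compound 1 stand within the scatter of one another, so neither can be called the more potent.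

Compound 3 `CCOc1ccc(NC(=O)/C=C/c2coc3cc(OC)ccc3c2=O)cc1` is the next amide: 4-ethoxyphenyl in place of 4-methylbenzyl on an amide-type nitrogen. Among the measured compounds shown here, the one step that bears on this change is a 1.7-fold lower number from compound 1 to compound 2 (0.24 log units; within the scatter), which also exchanged the group on the amide-type nitrogen and stayed within the scatter. On that basis no step beyond the scatter is expected in this assay from compound 2 to compound 3, in either direction. Compound 3 is therefore expected to give about 12000 nM, with a range from 5000 nM to 30000 nM. This estimate corresponds to a step of a 1.2-fold higher number from compound 2 to compound 3 (0.07 log units; within the scatter).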

Compound 3, half-maximal inhibitory concentration: > 100000 nM
Compound 3 gave a limit, no number; the forecaster's own chance of this, stated with the estimate: 10%; middle value at least 8.3-fold (0.92 log units) from the limit.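

In this assay compound 3 gives a limit and not a number: the limit of > 100000 nM in this assay, at which 1 of the 3 values shown sits.

Among the compounds shown here, the group on the amide-type nitrogen now clearly matters, since an at least 9.8-fold higher number from compound 2 to compound 3 (0.99 log units; beyond the scatter) and an at least 5.6-fold higher number from compound 1 to compound 3 (0.75 log units; beyond the scatter), whereas the only earlier step, a 1.7-fold lower number from compound 1 to compound 2 (0.24 log units; within the scatter), did not separate its two compounds. The comparison with compound 1 is the more telling one: 2-methoxyphenyl and 4-ethoxyphenyl both place an oxygen-bearing aromatic ring on that nitrogen, yet only the exchange to 4-ethoxyphenyl gives a step beyond the scatter, so the presence of such a ring alone does not set the read-out. With three compounds this remains an observation on these groups only and no general rule.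

The compounds shown do not tell whether the loss follows the ethoxy chain or its place on the ring, a question that 4-methoxyphenyl and 2-ethoxyphenyl would address. Also open, as far as these compounds go, are the full size of both steps, which the limit leaves unbounded, and how an amine or a carboxylic acid on the benzyl ring of compound 2 would read.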